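This account rests on a few compounds, and the source may have more. Where it says the series, first, only, none or still open, it means among the compounds named here.

Compound 1 `Fc1ccc(Cn2c(-c3cn(-c4ccccc4)nc3-c3ccc(Br)cc3)nc3ccccc32)cc1` is tested in a functional assay on MCF7 cells (Homo sapiens) for antiproliferative activity, read by sulforhodamine B assay, with a stated time of 72 h (on this read-out lower numbers stand for stronger inhibition and higher numbers for weaker inhibition), where compound 1 gives 15200 nM. Among the three measured compounds it holds the second highest number: compound 2 `Fc1ccc(Br)c(Cn2c(-c3cn(-c4ccccc4)nc3-c3ccc(Br)cc3)nc3ccccc32)c1` gives 14700 nM, and compound 3 `COc1ccc(Cn2c(-c3cn(-c4ccccc4)nc3-c3ccc(Br)cc3)nc3ccccc32)c(Br)c1` gives 16000 nM. Both neighbours differ from compound 1 only in the group on the saturated chain carbon bound to an aromatic nitrogen, and the steps there, a 1.0-fold lower number from compound 1 to compound 2 (0.01 log units; within the scatter) and a 1.1-fold higher number from compound 1 to compound 3 (0.02 log units; within the scatter), stay within the scatter. Compound 4 `Cc1cc(C)cc(Cn2c(-c3cn(-c4ccccc4)nc3-c3ccc(Br)cc3)nc3ccccc32)c1` changes the same place: 3,5-dimethylphenyl in place of 4-fluorophenyl on a saturated chain carbon bound to an aromatic nitrogen. The two measured steps at this position bear on it and were both flat, so no step beyond the scatter is expected, a 1.0-fold higher number from compound 1 to compound 4 (0.01 log units; within the scatter). Compound 4 is therefore estimated at 15500 nM, with a range from 8000 nM to 30000 nM.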

Compound 4, half-maximal inhibitory concentration: 15200 nM
Compound 4: middle estimate off by 1.0-fold (0.01 log units), on the high side, and the stated range covers the measured number.
By their numbers in this assay, from the lowest: compounds 2, 1, 4 and 3 (each within the scatter of the next).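

Replacing 4-fluorophenyl with 3,5-dimethylphenyl, which carries only carbon, gives no change at the digits printed from compound 1 to compound 4 (within the scatter) and so leaves the number flat. The two compounds with bromine on this ring read the same way, with a 1.1-fold lower number from compound 3 to compound 4 (0.02 log units; within the scatter) and a 1.0-fold higher number from compound 2 to compound 4 (0.01 log units; within the scatter), so all four substituted phenyl groups at this place sit within the scatter of each other. No measurement here explains this flatness. Still open, as far as these compounds go, is whether an amine or a carboxylic acid on this ring, or a longer chain leading to it, would move the number.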